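Amide-cap variation on a chloro-pyridyl aniline core

The source may report more compounds than this note shows. Statements on the series, on what has been measured and on what is new or still open speak of the compounds shown alone.

Measured in an assay on C3H 10T1/2 cells for inhibition of Sonic hedgehog protein (Mus musculus), read by a luciferase reporter (on this read-out higher numbers stand for weaker inhibition and lower numbers for stronger inhibition), so far:
compound 1 `O=C(Nc1ccc(Cl)c(-c2ccccn2)c1)c1ccncc1` — 700 nM
compound 2 `O=C(Nc1ccc(Cl)c(-c2ccccn2)c1)c1ccccc1` — 800 nM
compound 3 `O=C(Nc1ccc(Cl)c(-c2ccccn2)c1)c1ccc(Cl)cc1` — 1500 nM

All three share the same aniline core and differ only in the aryl group on the carbonyl carbon. Compound 3 has the highest number of the three. Its step from compound 2 is a 1.9-fold higher number from compound 2 to compound 3 (0.27 log units; within the scatter), so those two cannot be ordered; its step from compound 1 is a 2.1-fold higher number from compound 1 to compound 3 (0.33 log units; beyond the scatter), a modest difference. Compound 1 and compound 2 are separated by a 1.1-fold higher number from compound 1 to compound 2 (0.06 log units; within the scatter).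

Compound 4 `CS(=O)(=O)c1ccc(C(=O)Nc2ccc(Cl)c(-c3ccccn3)c2)cc1` is the next member, not yet measured in this assay. It differs from compound 3 by methylsulfonyl in place of chloro on an aromatic carbon. Among the measured compounds shown here, no measured step touches a methylsulfonyl group; the only step at this position is the one from compound 2 to compound 3, which was within the scatter, and the whole spread of the three numbers is narrow. Compound 4 is therefore expected to sit near compound 3, with a step of a 1.5-fold lower number from compound 3 to compound 4 (0.18 log units; within the scatter) that is not expected to exceed the scatter. The estimate for compound 4 in this assay is 1000 nM, with a range from 350 nM to 3000 nM.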

Compound 4, half-maximal inhibitory concentration: 40 nM
Compound 4: middle estimate off by 25-fold (1.40 log units), on the high side, outside the stated range (below it).
By their numbers in this assay, from the lowest: compound 4; then compounds 1, 2 and 3 (each within the scatter of the next, the first and the last beyond it).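

Methylsulfonyl in place of chloro gives a 38-fold lower number from compound 3 to compound 4 (1.57 log units; beyond the scatter) and methylsulfonyl in place of hydrogen gives a 20-fold lower number from compound 2 to compound 4 (1.30 log units; beyond the scatter) in this assay so this carbon, para to a large group, can carry a large change in the number. Chloro in place of hydrogen at the same carbon stayed within the scatter, so that step gave no sign of what methylsulfonyl does here, and the outcome at this position depends on which group enters. Among the compounds shown here, nothing measured so far accounts for the change.

Going by these compounds, how a sulfonamide, a carboxylic acid or a nitrile would compare with methylsulfonyl at this carbon stays open. Also open, on these data alone, is whether methylsulfonyl would have the same effect on a pyridin-4-yl cap like that of compound 1.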